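A few compounds are considered here, and "the series" means these few. Any claim that something is new, unique, unknown or untested is made for them only; others in the source may bear on it.

Measured so far:
compound 1 `N#Cc1cnc(NCc2cnccc2C(F)(F)F)cc1N[C@H]1C[C@H](O)C1` — 900 nM
compound 2 `N#Cc1cnc(NCc2cnccc2C(F)(F)F)cc1NC[C@H]1C[C@@H](O)C1` — 300 nM
compound 3 `N#Cc1cnc(NCc2cnccc2C(F)(F)F)cc1N[C@H]1CC[C@@H](O)CC1` — 100 nM

In an assay on isolated protein for inhibition of protein kinase C theta type (Homo sapiens), read by TR-FRET, with a stated time of 2 h (a lower number here means a stronger inhibitor, a higher number a weaker inhibitor), compound 3 gives the lowest number of the three, with a 3.0-fold lower number from compound 2 to compound 3 (0.48 log units; beyond the scatter) and a 9.0-fold lower number from compound 1 to compound 3 (0.95 log units; beyond the scatter). Compound 4 `N#Cc1cnc(NCc2cnccc2C(F)(F)F)cc1N[C@H]1CC[C@H](O)CC1` keeps every atom and bond of compound 3: the two compounds have the same atoms and bonds and differ only in configuration as drawn: 2 of 2 stereo elements differ (all stereocentres are inverted: mirror images); a stereocentre at a saturated ring carbon is drawn s in compound 3 and r in compound 4; a stereocentre at a saturated ring carbon is drawn s in compound 3 and r in compound 4. Going by the values given here, none of the measured steps bears directly on such a change, since each of them swaps one group on the nitrogen for another rather than turning a ring's configuration, so there is no measured step of this kind to lean on. The step is therefore expected to be small, a 2.0-fold higher number from compound 3 to compound 4 (0.30 log units; within the scatter), with a wide range on either side. Compound 4 is estimated at 200 nM, between 50 nM and 800 nM.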

Compound 4, half-maximal inhibitory concentration: 350 nM
For compound 4 the middle estimate is 1.8-fold (0.24 log units) below the measured one; measured number inside the range.
By their numbers in this assay, from the lowest: compound 3; then compounds 2 and 4 (each within the scatter of the next); then compound 1.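

On the 4-hydroxycyclohexyl group, configuration alone shifts the result, with a 3.5-fold higher number from compound 3 to compound 4 (0.54 log units; beyond the scatter), and the shift can be placed there because of one fact: the fact that compounds 3 and 4 differ only in the configuration as drawn. The edge of this group over (3-hydroxycyclobutyl)methyl therefore holds for only one configuration: with the other, there is a 1.2-fold higher number from compound 2 to compound 4 (0.07 log units; within the scatter). Against 3-hydroxycyclobutyl a smaller gain remains, with a 2.6-fold lower number from compound 1 to compound 4 (0.41 log units; beyond the scatter). Going by these compounds, whether the hydroxyl itself is needed stays open, as does whether an amine or a methoxy group in its place would give a similar number or a similar gap between configurations.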